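The compounds below may be only part of what the source reports. "The series", "measured", "known", "first", "only" and "open" are said of these compounds alone.

Compound 2 `Oc1cc(C(F)(F)F)ccc1-c1nc(-c2ccccc2O)n(-c2ccccc2C(F)(F)F)n1` was tested in a functional assay on PC-12 cells (Rattus norvegicus) for cytotoxicity, read by MTT assay, with stated times of 2 h and 24 h, tested at 10 uM (a higher number here means a stronger effect of the compound at the concentration tested, a lower number a weaker effect), and gave 92.2%. Going by the values given here, only one other compound has been measured: compound 1 `Oc1cc(C(F)(F)F)ccc1-c1nc(-c2ccccc2O)n(-c2ccccc2Cl)n1`, which in this assay gave 102%. The step of a number 9.8 percentage points lower from compound 1 to compound 2 (within the scatter) places compound 2 within the scatter of compound 1, so the two numbers cannot be told apart. Compound 3 `COc1ccccc1-n1nc(-c2ccc(C(F)(F)F)cc2O)nc1-c1ccccc1O` differs from compound 2 by methoxy in place of trifluoromethyl on an aromatic carbon. Among the compounds with values here, no measured step involves a methoxy group, so nothing bears directly on this change. Within the data shown here, the single measured step, trifluoromethyl in place of chloro on an aromatic carbon, left the read-out within the scatter, and the read-out of both compounds sits near the top of the scale. In the absence of any step beyond the scatter, the step from compound 2 to compound 3 in this assay is expected to be about a number 0.2 percentage points lower from compound 2 to compound 3 (within the scatter). For compound 3 the value in this assay is estimated at 92%, with a range from 72% to 106%.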

Compound 3, a percentage reported as activity, at one concentration (the size of the read-out at that concentration, not a potency): 96.2%
Beside the measured number, compound 3's estimate is 4.2 percentage points below it, within the range that was stated.
By their numbers in this assay, from the lowest: compounds 2, 3 and 1 (each within the scatter of the next).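

With methoxy, this position on the aromatic ring has now carried three different groups in this assay, and the new group leaves the read-out within the scatter of both others: a number 4 percentage points higher from compound 2 to compound 3 (within the scatter), and a number 5.8 percentage points lower from compound 1 to compound 3 (within the scatter). Unlike trifluoromethyl, methoxy has fewer heavy atoms and brings a hydrogen-bond acceptor, yet these differences come with no separable change in the read-out. So far, no exchange at this position has produced a difference larger than the scatter. No evidence is available on what lies behind these results.

On these data alone, it remains open whether an amine or a carboxylic acid at this position would move the read-out beyond the scatter. The compounds shown also leave open how changes elsewhere on the shared core, such as at either hydroxy group, would affect it.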